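The compounds below may be only part of what the source reports. "The series", "measured", "known", "first", "only" and "open" are said of these compounds alone.

Measured compounds in a functional assay on CHO cells for antagonist activity at prostaglandin E2 receptor EP1 subtype (Homo sapiens), read by FLIPR and calcium flux; on this read-out lower numbers stand for stronger inhibition and higher numbers for weaker inhibition:
compound 1, `CCOc1ccc(Cc2nnc(CN(c3cccc(Cl)c3C)S(=O)(=O)c3ccc(C)cc3)o2)cc1`, gives 50.1 nM
compound 2, `COc1ccc(Cc2nnc(CN(c3cccc(Cl)c3Cl)S(=O)(=O)c3ccc(C)cc3)o2)cc1`, gives 39.8 nM

Compound 2 holds the lowest of the two numbers recorded so far, but its nearest neighbour is compound 1, whose value in this assay lies within the scatter of compound 2, so no order between the two can be claimed. For the measured compounds named here, neither pair of measured compounds differs in a single place, so no step between measured compounds is available to lean on.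

Compound 3, `CCOc1ccc(Cc2nnc(CN(c3cccc(Cl)c3Cl)S(=O)(=O)c3ccc(C)cc3)o2)cc1`, has not yet been measured. It follows from compound 2 by the change (methyl in place of hydrogen on a saturated chain carbon bound to an oxygen on an aromatic ring), that is, methyl in place of hydrogen on a saturated chain carbon bound to an oxygen on an aromatic ring. Compound 1 already carries the ethoxy group that this change introduces, and in this assay it sits within the scatter of compound 2. On that basis the step in this assay from compound 2 to compound 3 is expected to be small, without a clear direction, and most likely not beyond the scatter.

Compound 3 is expected to give about 42 nM in this assay, within a range from 20 nM to 90 nM. This estimate implies a step of a 1.1-fold higher number from compound 2 to compound 3 (0.02 log units; within the scatter), expected to stay within the usual scatter.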

Compound 3, inhibition constant: 31.6 nM
For compound 3 the middle estimate is 1.3-fold (0.12 log units) above the measured one; measured number inside the range.
By their numbers in this assay, from the lowest: compounds 3, 2 and 1 (each within the scatter of the next).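

In this assay the change from methoxy to ethoxy can now be read directly, on the 4-methoxyphenyl group: a 1.3-fold lower number from compound 2 to compound 3 (0.10 log units; within the scatter) does not separate the two groups at this position. For the compounds shown here, the chloro in place of methyl on an aromatic carbon can also be read directly for the first time, and a 1.6-fold lower number from compound 1 to compound 3 (0.20 log units; within the scatter) likewise leaves those two groups unseparated on this read-out. Neither single-place change therefore gives a step beyond the scatter, and nothing available bears on the reason for either result.

On these data alone, whether a longer chain such as propoxy, or a carboxylic acid or an amine in place of the ethoxy group, would give a number clearly apart from these remains open. Also open, as far as these compounds go, is whether either change would keep its small size with other groups elsewhere on the shared core, since each has been read in only one setting.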